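Hydrazone series: halogen and hydroxy changes on the phenyl ring

The compounds below may be only part of what the source reports. "The series", "measured", "known", "first", "only" and "open" are said of these compounds alone.

The three measured compounds share one core and differ only on the phenyl ring of the hydrazone. Compound 1 `Cc1c(C(=O)N/N=C\c2ccccc2O)oc2cccc(O)c12` gives 10600 nM in a functional assay on MGC-803 cells (Homo sapiens) for inhibition, read by MTT assay; on this read-out higher numbers stand for weaker inhibition and lower numbers for stronger inhibition. Compound 2 `Cc1c(C(=O)N/N=C\c2cc(F)ccc2O)oc2cccc(O)c12` gives 5230 nM in this assay, and compound 3 `Cc1c(C(=O)N/N=C\c2ccc(O)cc2O)oc2cccc(O)c12` gives 7330 nM in this assay. Compound 3 thus stands second highest of the three numbers, and the steps to it, a 1.4-fold higher number from compound 2 to compound 3 (0.15 log units; within the scatter) and a 1.4-fold lower number from compound 1 to compound 3 (0.16 log units; within the scatter), are both within the scatter. Among the measured compounds shown here, the only step beyond the scatter in this set is a 2.0-fold lower number from compound 1 to compound 2 (0.31 log units; beyond the scatter).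

Compound 4 `Cc1c(C(=O)N/N=C\c2ccc(Br)cc2O)oc2cccc(O)c12` is the next member; it differs from compound 3 by bromo in place of hydroxy on an aromatic carbon. For the measured compounds named here, two measured steps bear on this change. Taking the hydroxy away, read in reverse, corresponds to a 1.4-fold lower number from compound 1 to compound 3 (0.16 log units; within the scatter), which is within the scatter. Putting a halogen on the ring, though at a different place, corresponds to a 2.0-fold lower number from compound 1 to compound 2 (0.31 log units; beyond the scatter), modest but beyond the scatter. Taken together they suggest a small move towards lower numbers in this assay, close to the edge of the scatter. Compound 4 is therefore expected to give 5000 nM, with a range from 2000 nM to 12000 nM. The expected step is a 1.5-fold lower number from compound 3 to compound 4 (0.17 log units; within the scatter).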

Compound 4, half-maximal inhibitory concentration: 5460 nM
Estimate against measurement, compound 4: 1.1-fold (0.04 log units) below; the measured number falls inside the stated range.
By their numbers in this assay, from the lowest: compounds 2, 4, 3 and 1 (each within the scatter of the next, the first and the last beyond it).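

At the ring position meta to a hydroxy group and para to a large group, bromo and hydroxy cannot be told apart in this assay (a 1.3-fold lower number from compound 3 to compound 4 (0.13 log units; within the scatter)), although hydroxy counts one hydrogen-bond donor and one acceptor and bromo counts neither. Bromo in place of hydrogen at this position also stays within the scatter (a 1.9-fold lower number from compound 1 to compound 4 (0.29 log units; within the scatter)), and the bromo and fluoro compounds, whose halogens sit at different places, cannot be separated (a 1.0-fold higher number from compound 2 to compound 4 (0.02 log units; within the scatter)), so this position has shown no change beyond the scatter, and the only such step in the series remains the fluoro one (a 2.0-fold lower number from compound 1 to compound 2 (0.31 log units; beyond the scatter)). No measurement of any property of these groups, or any other supporting data, accompanies these numbers to account for them.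

From the compounds shown here alone, it remains open whether any group at this position can move the number beyond the scatter, and an amine, a carboxylic acid or a longer chain such as propyl would put that to the test. Also open, going by these compounds, is how much the place of a halogen matters, which bromo at the position that fluoro holds in compound 2 would address directly.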